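Compound 2 and Its Acetoxy Counterpart, Compound 3

This account rests on a few compounds, and the source may have more. Where it says the series, first, only, none or still open, it means among the compounds named here.

Compound 1 `COc1ccc(-c2cc3c(OC)cc(OC)cc3n(CCC(=O)OCc3ccccc3)c2=O)cc1`: 10000 nM
Compound 2 `COc1cc(OC)c2cc(-c3ccc(O)cc3)c(=O)n(C)c2c1`: 10000 nM

In a functional assay on A549 cells (Homo sapiens) for cytotoxicity, read by colorimetric assay and MTT assay (a lower number here means a stronger inhibitor, a higher number a weaker inhibitor), compound 2 gives 10000 nM and stands level with compound 1 within the usual scatter. For the measured compounds named here, these two compounds differ in more than one place, so no measured step shows how a single change acts on this read-out.

Compound 3 `COc1cc(OC)c2cc(-c3ccc(OC(C)=O)cc3)c(=O)n(C)c2c1` has not yet been measured. It differs from compound 2 by one change, acetyl in place of hydrogen on an oxygen on an aromatic ring, or hydroxy to acetoxy.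

Going by the values given here, with no measured step to guide it, the expectation starts from compound 2 at 10000 nM and foresees no step beyond the scatter. The estimated step is no change at the digits printed from compound 2 to compound 3 (within the scatter). The expected value for compound 3 is 10000 nM, with an estimated range from 4000 nM to 25000 nM.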

Compound 3, half-maximal inhibitory concentration: 10000 nM
Beside the measured number, compound 3's estimate shows no gap at the digits printed, within the range that was stated.
By their numbers in this assay, from the lowest: compounds 1, 2 and 3 (each within the scatter of the next).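

In this assay the measured step reads no change at the digits printed from compound 2 to compound 3 (within the scatter) and gives the first view of a single change in this series. At this oxygen on the aromatic ring, acetyl and hydrogen are not told apart by this read-out, so going from hydroxy to acetoxy leaves the value where it stood. Nothing shown here offers an explanation for this result.

The compounds shown leave open whether another group on that oxygen, such as a longer acyl chain or a chain ending in an amine or a carboxylic acid, would move the value away from the level of compound 2 and compound 3. Going by these compounds, it also remains open what a single change elsewhere on the shared core does, as compound 1 and compound 2 differ in more than one place.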